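The source may report more compounds than this note shows. Statements on the series, on what has been measured and on what is new or still open speak of the compounds shown alone.

In a physicochemical assay for solubility, in phosphate buffer, at pH 6.5 (a lower number here means a less soluble compound, a higher number a more soluble compound), compound 1 `C=C[C@@H]1C[C@]1(NC(=O)[C@@H]1C[C@@H](Oc2nccc3cc(OC)ccc23)CN1C(=O)[C@@H](NC(=O)NC(C)(C)C)C(C)(C)C)C(=O)NS(=O)(=O)C1CC1` gives 13 ug/mL and compound 2 `C=C[C@@H]1C[C@]1(NC(=O)[C@@H]1C[C@@H](Oc2nccc3cc(OC)ccc23)CN1C(=O)[C@@H](NC(=O)N[C@@H](C)COC)C(C)(C)C)C(=O)NS(=O)(=O)C1CC1` gives 1070 ug/mL as the higher of the two numbers. Compound 3 `C=C[C@@H]1C[C@]1(NC(=O)[C@@H]1C[C@@H](Oc2nccc3cc(OC)ccc23)CN1C(=O)[C@@H](NC(=O)N[C@H](COC)C(C)(C)C)C(C)(C)C)C(=O)NS(=O)(=O)C1CC1` differs from compound 2 by tert-butyl in place of methyl on a saturated chain carbon bound to an amide-type nitrogen and a saturated chain carbon in one place: tert-butyl in place of methyl on a saturated chain carbon bound to an amide-type nitrogen and a saturated chain carbon. For the measured compounds named here, the one measured step bearing on this is the large 82-fold higher number from compound 1 to compound 2 (1.92 log units; beyond the scatter) with 1-(methoxymethyl)ethyl in place of tert-butyl on an amide-type nitrogen. A smaller move to a lower number in this assay is therefore expected, still beyond the scatter. The estimated change is an 8.9-fold lower number from compound 2 to compound 3 (0.95 log units; beyond the scatter) in size. Compound 3 is estimated at 120 ug/mL with an expected range from 25 ug/mL to 500 ug/mL in this measurement.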

Compound 3, solubility: 609 ug/mL
Estimate against measurement, compound 3: 5.1-fold (0.71 log units) below, and the stated range ends below it.
By their numbers in this assay, from the lowest: compound 1; then compounds 3 and 2 (each within the scatter of the next).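

With tert-butyl in place of methyl on a saturated chain carbon bound to an amide-type nitrogen and a saturated chain carbon, this assay shows a 1.8-fold lower number from compound 2 to compound 3 (0.24 log units; within the scatter) and so does not separate the two chains. The large gain over the plain tert-butyl group also holds for 1-(methoxymethyl)-2,2-dimethylpropyl in place of tert-butyl on an amide-type nitrogen, with a 47-fold higher number from compound 1 to compound 3 (1.67 log units; beyond the scatter) in this assay as the step. No available evidence explains either step.

Still open, from the compounds shown here alone, is how a hydroxymethyl or a dimethylamino group in place of methoxymethyl would read in this assay on this chain.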